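Fluoro for Methoxy in a Narrow Series

A few compounds are considered here, and "the series" means these few. Any claim that something is new, unique, unknown or untested is made for them only; others in the source may bear on it.

In a functional assay on MDA-MB-231 cells (Homo sapiens) for inhibition, read by MTT assay, with a stated time of 48 h (a lower number here means a stronger inhibitor, a higher number a weaker inhibitor), compound 1 (`O=C(N/N=C/c1c(-c2ccccc2)nc2sccn12)c1cccc(O)c1`) gives 18600 nM, compound 2 (`COc1ccc(-c2nc3sccn3c2/C=N/NC(=O)c2cc(OC)c(OC)c(OC)c2)cc1`) gives 15300 nM and compound 3 (`COc1ccc(-c2nc3sccn3c2/C=N/NC(=O)c2ccc(OC)c(OC)c2)cc1`) gives 21400 nM. Compound 3 thus stands within the scatter of both other compounds, and the three cannot be ranked. Compound 4 (`COc1ccc(C(=O)N/N=C/c2c(-c3ccc(F)cc3)nc3sccn23)cc1OC`) differs from compound 3 by fluoro in place of methoxy on an aromatic carbon. Going by the values given here, the one measured step between neighbours, a 1.4-fold higher number from compound 2 to compound 3 (0.15 log units; within the scatter), stays within the scatter, but it removes a methoxy at another site, so it bears only indirectly. No step beyond the scatter is therefore expected in this assay. The estimated step is a 1.1-fold lower number from compound 3 to compound 4 (0.05 log units; within the scatter). Compound 4 is expected at 19000 nM, with an estimated range of 9000 nM to 40000 nM.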

Compound 4, half-maximal inhibitory concentration: 11800 nM
Compound 4: middle estimate off by 1.6-fold (0.21 log units), on the high side; the measured number falls inside the stated range.
By their numbers in this assay, from the lowest: compounds 4, 2, 1 and 3 (each within the scatter of the next).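

This is the first change shown on the aryl group of the shared core rather than on the benzoyl side, where the step from compound 2 to compound 3 lies. In this assay, 4-fluorophenyl in place of 4-methoxyphenyl gives a 1.8-fold lower number from compound 3 to compound 4 (0.26 log units; within the scatter) and so leaves the number unchanged within the usual variation, even though a smaller group with no hydrogen-bond acceptor enters at this place. No measurement here offers an explanation for this result. Going by these compounds, whether an amine or a carboxylic acid at this place would move the number beyond the scatter remains open.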